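A few compounds are considered here, and "the series" means these few. Any claim that something is new, unique, unknown or untested is made for them only; others in the source may bear on it.

Compound 1, `COc1ccc(CNc2nc3cc(N)cc(N)c3nc2-c2ccccc2)cc1OC`, in a functional assay on TK-10 cells (Homo sapiens) for inhibition, read by sulforhodamine B assay, with a stated time of 48 h (a lower number here means that less compound is tolerated, a higher number that more compound is tolerated), gives 64600 nM.
Compound 2, `Nc1cc(N)c2nc(-c3ccccc3)c(NCc3ccc(F)cc3)nc2c1`, in this assay gives 53700 nM.

Among the measured compounds shown here, of these two numbers, compound 2 has the lower one, but the only other compound, compound 1, sits so close that the step of a 1.2-fold lower number from compound 1 to compound 2 (0.08 log units; within the scatter) stays within the usual scatter, so the two cannot be ordered. Compound 3, `COc1ccc(CNc2nc3cc(N)cc(N)c3nc2-c2ccccc2)cc1`, differs from compound 2 by methoxy in place of fluoro on an aromatic carbon. For the measured compounds named here, no measured step exchanges fluoro for methoxy directly. Going by the values given here, the one step that bears on the change is a 1.2-fold lower number from compound 1 to compound 2 (0.08 log units; within the scatter), which swapped 3,4-dimethoxyphenyl for 4-fluorophenyl at the same place without moving the number beyond the scatter. A ring carrying a single methoxy resembles both of those cases, so the step of a 1.1-fold higher number from compound 2 to compound 3 (0.03 log units; within the scatter) is expected to amount to nothing beyond the scatter. Compound 3 is therefore estimated at 58000 nM, with a range from 30000 nM to 110000 nM.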

Compound 3, concentration lethal to 50% of the cells: < 100000 nM
Compound 3: no number, only a limit; the forecaster's own chance of this, stated with the estimate: 10%; the middle value does not contradict the limit.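

In this assay compound 3 gives < 100000 nM, which is a limit and not a number, so its steps from compound 1 and from compound 2 cannot be read. On these data alone, whether methoxy in place of fluoro shifts the number at all therefore stays open.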